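Hydrogen in Place of 4-Methoxybenzyl: Two Matched Pairs

A few compounds are considered here, and "the series" means these few. Any claim that something is new, unique, unknown or untested is made for them only; others in the source may bear on it.

The study follows growth inhibition in a functional assay on U-937 cells (Homo sapiens) for inhibition, read by MTT assay, with a stated time of 24 h (on this read-out higher numbers stand for weaker inhibition of growth and lower numbers for stronger inhibition of growth), across four closely related ureas. Compound 1, `COc1ccc(Cn2ncc3c2NC(=O)CC(c2ccc(NC(=O)Nc4ccc(Cl)c(C(F)(F)F)c4)cc2)=N3)cc1`, gives 7290 nM in this assay. Compound 2, `O=C1CC(c2ccc(NC(=O)Nc3ccc(Cl)c(C(F)(F)F)c3)cc2)=Nc2cn[nH]c2N1`, is made from it by the change (hydrogen in place of 4-methoxybenzyl on an aromatic nitrogen). In this assay compound 2 reaches only > 30000 nM, which is a limit of the assay and not a number. The step from compound 1 to compound 2 is therefore an at least 4.1-fold higher number from compound 1 to compound 2 (0.61 log units; beyond the scatter), and its size can only be given as a floor because of the limit of > 30000 nM in this assay, at which 1 of the 3 values shown sits.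

Compound 3, `COc1ccc(Cn2ncc3c2NC(=O)CC(c2cccc(NC(=O)Nc4ccc(Cl)c(Cl)c4)c2)=N3)cc1`, gives 14900 nM in this assay, a higher number than compound 1. The difference between the cores of compound 1 and compound 3 is not broken down here.

Compound 4, `O=C1CC(c2cccc(NC(=O)Nc3ccc(Cl)c(Cl)c3)c2)=Nc2cn[nH]c2N1`, is related to compound 3 by hydrogen in place of 4-methoxybenzyl on an aromatic nitrogen, the same change, at the same place, as that from compound 1 to compound 2. Compound 3 already starts from a weaker position than compound 1, and the earlier pair lost at least modest potency on removing the 4-methoxybenzyl group. The step from compound 3 to compound 4 is expected to be a 4.0-fold higher number from compound 3 to compound 4 (0.60 log units; beyond the scatter), resting on the measured step of an at least 4.1-fold higher number from compound 1 to compound 2 (0.61 log units; beyond the scatter). Compound 4 is thus estimated at 60000 nM, with a likely range from 25000 nM to 150000 nM, and the assay is expected most often to report only a limit for it.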

Compound 4, concentration for 50% growth inhibition: > 30000 nM
Compound 4 ended at the assay's limit; the forecaster's own chance of this, stated with the estimate: 80%; the middle value is on the limit's open side.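

In this assay compound 4 gives > 30000 nM, which is a limit of the assay and not a number. On this second core, hydrogen in place of 4-methoxybenzyl on the aromatic nitrogen gives an at least 2.0-fold higher number from compound 3 to compound 4 (0.30 log units; that floor lies within the scatter), so the number does not fall on losing the group on either core shown, but this step is only a floor and does not by itself establish a change beyond the scatter. The two pairs therefore show that the loss seen on the first core is not contradicted on the second, but they do not show that the change carries over with the same size, since only two floors are available for comparison: the same change on two cores in this assay, an at least 4.1-fold higher number (0.61 log units; beyond the scatter) from compound 1 to compound 2 and an at least 2.0-fold higher number (0.30 log units; that floor lies within the scatter) from compound 3 to compound 4; the limit leaves it open whether they differ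

Going by these compounds, on both cores the aromatic nitrogen carries only 4-methoxybenzyl or hydrogen, so it stays open whether a methyl group, a plain benzyl group or a benzyl group bearing an amine or a carboxylic acid would give values closer to those of compound 1 and compound 3 or closer to the hydrogen compounds. Also open are the actual potencies of compound 2 and compound 4, which these figures cannot place: the limit of > 30000 nM in this assay, at which 2 of the 4 values shown sit.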